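Methyl on the nitrogen of compound 2: an expectation

A few compounds are considered here, and "the series" means these few. Any claim that something is new, unique, unknown or untested is made for them only; others in the source may bear on it.

In a functional assay, read by chemiluminescence (on this read-out lower numbers stand for stronger inhibition and higher numbers for weaker inhibition), compound 1 `COC(=O)CCC1CNc2cc(O)ccc21` gives 1380 nM and compound 2 `O=C(O)CCC1CNc2cc(O)ccc21` gives 1340 nM. Compound 2 has only compound 1 for comparison, and the two values lie within the scatter of each other.

Compound 3 `CN1CC(CCC(=O)O)c2ccc(O)cc21` differs from compound 2 by methyl in place of hydrogen on a nitrogen on an aromatic ring in a ring. Within the data shown here, the only measured step, a 1.0-fold lower number from compound 1 to compound 2 (0.01 log units; within the scatter), sits at another place in the structure. Among the measured compounds shown here, it offers no direct guide to a change on the nitrogen, and no measurement yet covers that position, so the range is kept wide.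

The step expected in this assay is a 1.1-fold higher number from compound 2 to compound 3 (0.05 log units; within the scatter), which means none beyond the scatter and no firm direction. For compound 3 the expected value is 1500 nM, with an estimated range of 500 nM to 4500 nM.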

Compound 3, half-maximal inhibitory concentration: 3250 nM
Estimate against measurement, compound 3: 2.2-fold (0.34 log units) below, and the stated range covers the measured number.
By their numbers in this assay, from the lowest: compounds 2 and 1 (each within the scatter of the next); then compound 3.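

Among these compounds, the nitrogen on an aromatic ring is the first place where a single change moves the number beyond the scatter: in this assay the step is a 2.4-fold higher number from compound 2 to compound 3 (0.38 log units; beyond the scatter) and points toward weaker inhibition, though only modestly. Among the compounds shown here, the earlier step, a 1.0-fold lower number from compound 1 to compound 2 (0.01 log units; within the scatter), sat at another place in the structure and showed no change, so this nitrogen is the only position so far at which the read-out responds, and the hydrogen there cannot be swapped for methyl without a cost. No measurement in hand bears on why the number rises.

Still open, going by these compounds, is whether ethyl or acetyl on this nitrogen would carry the step further or bring the number back toward that of compound 2. Also open, on these data alone, is whether methyl on the nitrogen would have the same effect with a methyl ester or a primary amide in place of the carboxylic acid.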